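(4-Methylphenyl)sulfonyl in place of methyl in compound 3

The compounds below may be only part of what the source reports. "The series", "measured", "known", "first", "only" and "open" are said of these compounds alone.

In an ADME assay on L02 cells (Homo sapiens) for cytotoxicity, read by MTT assay, with a stated time of 24 h (a lower number here means a stronger inhibitor, a higher number a weaker inhibitor), compound 1 (`CN1C/C(=C\c2cccnc2)C(=O)/C(=C/c2ccccc2C(F)(F)F)C1`) gives 14100 nM and compound 2 (`CN1C/C(=C\c2ccncc2)C(=O)/C(=C/c2ccccc2F)C1`) gives 14900 nM while compound 3 (`CN1C/C(=C\c2ccncc2)C(=O)/C(=C/c2ccccc2C(F)(F)F)C1`) gives 15800 nM on this scale. Compound 3 therefore stands level with both others: pyridin-4-yl in place of pyridin-3-yl gives a 1.1-fold higher number from compound 1 to compound 3 (0.05 log units; within the scatter) and trifluoromethyl in place of fluoro gives a 1.1-fold higher number from compound 2 to compound 3 (0.03 log units; within the scatter) without separating them. Compound 4 (`Cc1ccc(S(=O)(=O)N2C/C(=C\c3ccncc3)C(=O)/C(=C/c3ccccc3C(F)(F)F)C2)cc1`) carries (4-methylphenyl)sulfonyl in place of methyl on an amine nitrogen in a ring. Neither measured step touches that nitrogen, so the data give no direct size for this change, and only a tentative move toward a lower number is expected. In this assay the expected change is a 1.8-fold lower number from compound 3 to compound 4 (0.24 log units; within the scatter) with a wide margin. The estimate for compound 4 is 9000 nM (range 3000 nM to 28000 nM).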

Compound 4, half-maximal inhibitory concentration: 12800 nM
Estimate against measurement, compound 4: 1.4-fold (0.15 log units) below; the measured number falls inside the stated range.
By their numbers in this assay, from the lowest: compounds 4, 1, 2 and 3 (each within the scatter of the next).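

In this assay, the change on the amine nitrogen in a ring gives a 1.2-fold lower number from compound 3 to compound 4 (0.09 log units; within the scatter). For the compounds shown here, this is the first reading at this position, and it shows that a (4-methylphenyl)sulfonyl group, with its aromatic ring and two added hydrogen-bond acceptors, leaves the number within the scatter of the methyl compound. The data shown offer no explanation for this result.

The compounds shown leave open whether the bare secondary amine, an acetyl group or a benzyl group on this nitrogen would read the same. They also leave open whether the same change would hold with pyridin-3-yl or fluoro elsewhere on the core.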